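The source may report more compounds than this note shows. Statements on the series, on what has been measured and on what is new or still open speak of the compounds shown alone.

Measured compounds:
- Compound 1 `Cc1cc(C)c2cccc(OCc3c(Cl)ccc(S(=O)(=O)NC4(C(=O)N5CCN(C(=O)[C@H](CCCC[N+](C)(C)C)[N+](C)(C)C)CC5)CCCC4)c3Cl)c2n1`: in an assay on isolated protein for binding affinity to B1 bradykinin receptor (Homo sapiens) (a higher number here means a weaker inhibitor, a lower number a stronger inhibitor), compound 1 is reported only as a limit, < 10000 nM.
- Compound 2 `Cc1cc(C)c2cccc(OCc3c(Cl)ccc(S(=O)(=O)NC4(C(=O)N5CCN(C(=O)C[C@@H](N)CCC[N+](C)(C)C)CC5)CCCC4)c3Cl)c2n1`: in this assay compound 2 is likewise reported only as a limit, < 10000 nM.

Within the data shown here, compound 2 therefore stands on a limit, not on a number, and the one further value shown for this assay is a limit as well, so that both recorded values sit at the same edge of the measurable range (the limit of < 10000 nM in this assay, at which 2 of the 2 values shown sit). No step between two measured compounds can be formed from such values, and the size or direction of any structural change in this assay remains unknown from the numbers shown.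

Compound 3 `Cc1cc(C)c2cccc(OCc3c(Cl)ccc(S(=O)(=O)NC4(C(=O)N5CCN(C(=O)CCCC[N+](C)(C)C)CC5)CCCC4)c3Cl)c2n1` is the next compound to be considered. It differs from compound 2 by a group of 7 heavy atoms (6 carbon, 1 nitrogen; no ring) in place of a group of 9 heavy atoms (7 carbon, 2 nitrogen; no ring), on a saturated chain carbon bound to a carbonyl carbon. Among the measured compounds shown here, since no measured step exists to guide the expectation, the step from compound 2 to compound 3 is expected to be a step that the limit leaves unreadable from compound 2 to compound 3, with no clear direction beyond the scatter. On that basis compound 3 is expected to give an inhibition constant near 2000 nM, within a wide range from 200 nM to 10000 nM, and a fair chance remains that this assay again reports only a limit for compound 3.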

Compound 3, inhibition constant: < 10000 nM
Compound 3 gave a limit, no number; the forecaster's own chance of this, stated with the estimate: 60%; the middle value does not contradict the limit.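

In this assay compound 3 is reported only as a limit (< 10000 nM). No step can be read between compound 2 and compound 3, as all values shown stand at one edge of the range: the limit of < 10000 nM in this assay, at which 3 of the 3 values shown sit. The compounds shown leave open how strongly any of the three binds the receptor, and whether exchanging the group on the saturated chain carbon bound to a carbonyl carbon changes that binding at all.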